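Bromo for Chloro at a Distal Phenyl Ring

The compounds below may be only part of what the source reports. "The series", "measured", "known", "first", "only" and "open" are said of these compounds alone.

Of the compounds shown here, three share a trimethoxyphenyl vinyl sulfone core and have been tested in a functional assay on K562 cells (Homo sapiens) for cytotoxicity, read by trypan blue exclusion, with a stated time of 96 h; a lower number here means a stronger inhibitor, a higher number a weaker inhibitor. Compound 2 `COc1cc(OC)c(/C=C/S(=O)(=O)Cc2ccc(Cl)c(N)c2)c(OC)c1` gives 10 nM, and compound 1 `COc1cc(OC)c(/C=C/S(=O)(=O)Cc2ccc(Br)c(N)c2)c(OC)c1` gives 750 nM. The step of a 75-fold higher number from compound 2 to compound 1 (1.88 log units; beyond the scatter) corresponds to a single change, (bromo in place of chloro on an aromatic carbon). Compound 3 `COc1cc(OC)c(/C=C/S(=O)(=O)Cc2ccc(OC)c(NC(C(=O)O)c3ccc(Cl)cc3)c2)c(OC)c1` gives 250 nM, which stands between the other two; the difference between the core of compound 3 and that of compound 2 is not broken down here.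

Compound 4 `COc1cc(OC)c(/C=C/S(=O)(=O)Cc2ccc(OC)c(NC(C(=O)O)c3ccc(Br)cc3)c2)c(OC)c1` has not yet been measured in this assay. It differs from compound 3 by bromo in place of chloro on an aromatic carbon. This is the same kind of change as that from compound 2 to compound 1, but not the same: there the aromatic carbon was ortho to an amino group (1 heavy atom) and para to a large group, whereas here it is only para to a large group, on a separate 4-chlorophenyl ring that becomes 4-bromophenyl.

Going by the values given here, the one precedent, a 75-fold higher number from compound 2 to compound 1 (1.88 log units; beyond the scatter), points toward a higher number. Among the compounds with values here, since the setting differs and only one such step is known, the expected step of a 2.8-fold higher number from compound 3 to compound 4 (0.45 log units; beyond the scatter) is estimated to be smaller than that precedent. Compound 4 is therefore expected to give about 700 nM in this assay, with a range estimated from 200 nM to 5000 nM.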

Compound 4, half-maximal inhibitory concentration: 200 nM
The estimate for compound 4 lay 3.5-fold (0.54 log units) above the measured number; low and high end bracket the measured number.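

In this assay, bromo in place of chloro on the 4-chlorophenyl ring gives a 1.3-fold lower number from compound 3 to compound 4 (0.10 log units; within the scatter), so on this core the exchange leaves the number unchanged within the usual scatter. Set beside the earlier step, the same exchange did not carry over from one core to the other: the same change on two cores in this assay, a 75-fold higher number (1.88 log units; beyond the scatter) from compound 2 to compound 1 and a 1.3-fold lower number (0.10 log units; within the scatter) from compound 3 to compound 4, 94-fold (1.97 log units) apart, beyond the scatter of two such steps. Going by these compounds alone, the large step of a 75-fold higher number from compound 2 to compound 1 (1.88 log units; beyond the scatter) therefore cannot be treated as a general result of putting bromo in place of chloro, but with only one pair on each core, the data do not show whether the gap follows from the ring that carries the halogen or from some other difference between the two cores, nor how the exchange would read on a third core.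

The compounds shown leave open how fluoro, iodo or methyl in the same place would read on either core. They also leave open whether the exchange on the 4-chlorophenyl ring would stay within the scatter if a methyl ester or an amide stood in place of the carboxylic acid.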